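The source may report more compounds than this note shows. Statements on the series, on what has been measured and on what is new or still open speak of the compounds shown alone.

Working notes on the series in an ADME assay on a cell-free system (plasma, Homo sapiens) for metabolic stability, with Plasma (Rattus norvegicus) as the target, read by HPLC, at pH 7.4; on this read-out lower numbers stand for a shorter-lived compound and higher numbers for a longer-lived compound. Compound 1 `CC(=O)Oc1ccccc1C(=O)O[C@H]1CO[C@H]2[C@@H]1OC[C@H]2OC(=O)c1ccccc1O` gives 0.019 h. Compound 2 `CC(=O)Oc1ccccc1C(=O)O[C@H]1CO[C@H]2[C@@H]1OC[C@H]2O`, which carries hydrogen in place of (2-hydroxyphenyl)carbonyl on an oxygen on a saturated carbon, gives 0.0183 h; compound 3 `CC(=O)Oc1ccccc1C(=O)O[C@H]1CO[C@H]2[C@@H]1OC[C@H]2OC(C)=O`, with methyl in place of 2-hydroxyphenyl on a carbonyl carbon, gives 0.0095 h. On these numbers compound 1 is set apart from compound 2 by a 1.0-fold lower number from compound 1 to compound 2 (0.02 log units; within the scatter) and from compound 3 by a 2.0-fold lower number from compound 1 to compound 3 (0.30 log units; within the scatter), and the step of a 1.9-fold lower number from compound 2 to compound 3 (0.28 log units; within the scatter) is of the same order, so none of the three compounds is separated from another beyond the scatter.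

Compound 4 `CC(=O)Oc1ccccc1C(=O)O[C@H]1CO[C@H]2[C@@H]1OC[C@H]2OC(=O)c1ccc(C)cc1` is the next point. Its change from compound 1 is 4-methylphenyl in place of 2-hydroxyphenyl on a carbonyl carbon. Going by the values given here, two measured steps bear on it. The step of a 2.0-fold lower number from compound 1 to compound 3 (0.30 log units; within the scatter) replaces the same 2-hydroxyphenyl on the same carbonyl carbon, and the step of a 1.0-fold lower number from compound 1 to compound 2 (0.02 log units; within the scatter) removes the whole (2-hydroxyphenyl)carbonyl; neither moves the half-life beyond the scatter. The expected step is therefore none beyond the scatter, a 1.3-fold lower number from compound 1 to compound 4 (0.10 log units; within the scatter), with a lean toward the shorter-lived side because both a 2.0-fold lower number from compound 1 to compound 3 (0.30 log units; within the scatter) and a 1.0-fold lower number from compound 1 to compound 2 (0.02 log units; within the scatter) point that way within the scatter. Compound 4 is expected at 0.015 h, within 0.007 h to 0.035 h.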

Compound 4, half-life: 0.0362 h
Estimate against measurement, compound 4: 2.4-fold (0.38 log units) below; measured number outside the range, above it.
By their numbers in this assay, from the lowest: compounds 3, 2, 1 and 4 (each within the scatter of the next, the first and the last beyond it).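

In this assay, this carbonyl carbon gives the first separation beyond the scatter in the series, a modest one: 4-methylphenyl in place of methyl gives a 3.8-fold higher number from compound 3 to compound 4 (0.58 log units; beyond the scatter) and so sets the two substituents on this carbonyl apart. The exchange of one aromatic ring for the other (a 1.9-fold higher number from compound 1 to compound 4 (0.28 log units; within the scatter)) and the addition of the whole (4-methylphenyl)carbonyl to the oxygen on a saturated carbon (a 2.0-fold higher number from compound 2 to compound 4 (0.30 log units; within the scatter)) both stay within the scatter, so the hydrogen-bond donor and acceptor counted on 2-hydroxyphenyl and absent from 4-methylphenyl cannot be tied to any resolved change in half-life. Going by these compounds alone, nothing among the data given speaks to the origin of the one resolved step.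

With only methyl, 2-hydroxyphenyl and 4-methylphenyl on this carbonyl carbon, the compounds shown do not tell whether the separation follows the aromatic ring itself or the 4-methyl group on it. Also open, from the compounds shown here alone, is how the half-life responds to a longer alkyl chain on this carbonyl carbon, or to an amine or a carboxylic acid carried on the phenyl ring.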